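A Single Measured Value and One Exchanged Group

This account rests on a few compounds, and the source may have more. Where it says the series, first, only, none or still open, it means among the compounds named here.

Measured compounds in a functional assay (aorta) with Rattus norvegicus as the target; a higher number here means that more compound is needed for the effect, a lower number that less compound is needed:
- compound 1 `CC(C)C[C@@H](N)C(=O)Nc1cc2cc[nH]c(=O)c2cc1Cl`: 700 nM
- compound 2 `CN(C)[C@H]1CC[C@@H](C(=O)Nc2cc3cc[nH]c(=O)c3cc2Cl)CC1`: "not determined" (no result reported)

Among the compounds with values here, compound 1 stands alone on the numbers: at 700 nM it holds the only value in this assay, so it cannot be ranked against anything. Within the data shown here, compound 2 shares the core of compound 1 but offers no number to compare, and no step between measured compounds exists to show how this series responds to a change in this group.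

Compound 3 `CN1CCC(C(=O)Nc2cc3cc[nH]c(=O)c3cc2Cl)CC1` keeps the shared core and carries 1-methylpiperidin-4-yl in place of 1-amino-3-methylbutyl on a carbonyl carbon. With so little measured, any forecast starts from compound 1 at 700 nM and remains uncertain. A modest move towards needing more compound seems likeliest, although a result within the usual scatter would be no surprise. The expected change is a 2.1-fold higher number from compound 1 to compound 3 (0.33 log units; beyond the scatter). For compound 3 the estimated value is 1500 nM, with an expected range from 300 nM to 7000 nM.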

Compound 3, half-maximal effective concentration: 250 nM
For compound 3 the middle estimate is 6.0-fold (0.78 log units) above the measured one, and the stated range ends above it.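

In this assay, the place on the carbonyl carbon proves responsive to the group it carries: 1-methylpiperidin-4-yl in place of 1-amino-3-methylbutyl gives a 2.8-fold lower number from compound 1 to compound 3 (0.45 log units; beyond the scatter) and so shows that this position accepts a six-membered non-aromatic ring with one hetero atom where compound 1 has an open chain. The exchange alters several things at once, as the ring enters while the hydrogen-bond donor and the defined stereocentre of 1-amino-3-methylbutyl leave, and this single step cannot assign the change to any one of them. Nothing available explains the direction or size of this change.

The compounds shown leave open which of these features matters, for instance whether a piperidin-4-yl group with a hydrogen on the ring nitrogen, a 1-ethylpiperidin-4-yl group or an open-chain tertiary amine would behave like the group in compound 3. They also leave open whether the ring nitrogen is needed at all, which a plain cyclohexyl group or a tetrahydropyran-4-yl group on the same carbonyl carbon would help to settle.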